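Aryl swap at the saturated ring carbon: compound 3

The compounds below may be only part of what the source reports. "The series", "measured", "known", "first", "only" and "open" are said of these compounds alone.

Among the compounds with values here, in a functional assay on the whole organism (strain Wister albino) for inhibition, with Rattus norvegicus as the target, read by paw edema, with a stated time of 1 h, at a dose of 50 mg/kg by the intraperitoneal route (on this read-out higher numbers stand for more inhibition at the one dose given (going by the name of the read-out) and lower numbers for less inhibition), compound 2 `CN1C[C@@H](c2ccco2)[C@@]2(Cc3ccccc3C2=O)[C@@]12C(=O)Nc1ccccc12` gives 48.8%, which places it at the bottom of the two numbers so far, though the scatter does not separate it from compound 1 `CN1C[C@@H](c2ccccc2)[C@@]2(Cc3ccccc3C2=O)[C@@]12C(=O)Nc1ccccc12`, which gives 56% in this assay. The step of a number 7.2 percentage points lower from compound 1 to compound 2 (within the scatter) stayed inside the scatter. Compound 3 `COc1ccc([C@@H]2CN(C)[C@]3(C(=O)Nc4ccccc43)[C@]23Cc2ccccc2C3=O)cc1` carries 4-methoxyphenyl in place of furan-2-yl on a saturated ring carbon. Within the data shown here, the only measured step bearing on this change is that aryl exchange, and it did not move the read-out beyond the scatter, so no step beyond the scatter is expected in this assay. Compound 3 is expected to give 53%, within 40% to 66%. The expected step is a number 4.2 percentage points higher from compound 2 to compound 3 (within the scatter).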

Compound 3, a percentage reported as inhibition, in the whole organism at one dose (the size of the read-out at that dose, not a potency): 41.2%
Compound 3: middle estimate off by 11.8 percentage points, on the high side; the range from low to high includes it.
By their numbers in this assay, from the lowest: compounds 3, 2 and 1 (each within the scatter of the next, the first and the last beyond it).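

In this assay, within the data shown here, methoxy in place of hydrogen on the aromatic ring gives the first step beyond the scatter (a number 14.8 percentage points lower from compound 1 to compound 3 (beyond the scatter)), while the exchange of furan-2-yl for 4-methoxyphenyl stays inside it (a number 7.6 percentage points lower from compound 2 to compound 3 (within the scatter)). Of the three aryl groups, only phenyl and 4-methoxyphenyl are therefore separated, with less inhibition where the methoxy is present. No measurement at hand accounts for this step. Open, on these data alone, is whether an amine or a carboxylic acid in place of the methoxy would move the read-out, and whether the step depends on where the methoxy sits on the ring.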